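This account rests on a few compounds, and the source may have more. Where it says the series, first, only, none or still open, it means among the compounds named here.

The measured compounds and their numbers in an assay on isolated protein for inhibition of glutathione S-transferase Mu 2 (Homo sapiens), with a stated time of 10 min; a higher number here means a weaker inhibitor, a lower number a stronger inhibitor:

Compound 1 `O=C(O)CCC(=O)OCCCCCCSc1ccc([N+](=O)[O-])c2nonc12` gives 160 nM.
Compound 2 `Cc1ccccc1NC(=O)CCC(=O)OCCCCCCSc1ccc([N+](=O)[O-])c2nonc12` gives 440 nM.
Compound 3 `COc1ccc(NC(=O)CCC(=O)OCCCCCCSc2ccc([N+](=O)[O-])c3nonc23)cc1` gives 130 nM.

Among these three, compound 1 stands second highest. Its nearest neighbour is compound 3, and the step of a 1.2-fold lower number from compound 1 to compound 3 (0.09 log units; within the scatter) lies within the scatter, so the two cannot be ordered. The furthest is compound 2, reached by a 2.8-fold higher number from compound 1 to compound 2 (0.44 log units; beyond the scatter), a modest step beyond the scatter. Between the two anilides, a 3.4-fold lower number from compound 2 to compound 3 (0.53 log units; beyond the scatter) shows the same modest gap from the other side.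

Compound 4 `COc1ccc(NC(=O)CCC(=O)OCCCCCCSc2ccc([N+](=O)[O-])c3nonc23)cc1OC` has not yet been measured in this assay. Compared with compound 1 the change is (3,4-dimethoxyphenyl)amino in place of hydroxy on a carbonyl carbon.

Going by the values given here, the steps that bear on this are those that replace the hydroxy on the carbonyl carbon with an arylamino group: a 2.8-fold higher number from compound 1 to compound 2 (0.44 log units; beyond the scatter) went modestly up, while a 1.2-fold lower number from compound 1 to compound 3 (0.09 log units; within the scatter) stayed within the scatter. Compound 4 carries a (3,4-dimethoxyphenyl)amino group, which is closer in kind to the (4-methoxyphenyl)amino of compound 3 than to the (2-methylphenyl)amino of compound 2, and the estimate therefore rests on the latter step: the expected step is a 1.1-fold lower number from compound 1 to compound 4 (0.03 log units; within the scatter), that is, no change beyond the scatter. For compound 4 the estimated value in this assay is 150 nM, with a range from 60 nM to 380 nM.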

Compound 4, half-maximal inhibitory concentration: 360 nM
Beside the measured number, compound 4's estimate is 2.4-fold (0.38 log units) below it; the range from low to high includes it.
By their numbers in this assay, from the lowest: compounds 3 and 1 (each within the scatter of the next); then compounds 4 and 2 (each within the scatter of the next).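

In this assay, methoxy in place of hydrogen on an aromatic carbon gives a 2.8-fold higher number from compound 3 to compound 4 (0.44 log units; beyond the scatter). This shows that the close match between compound 3 and compound 1 does not carry over to every arylamino group on this carbonyl carbon. The (3,4-dimethoxyphenyl)amino group gives a 2.3-fold higher number from compound 1 to compound 4 (0.35 log units; beyond the scatter) and places compound 4 on the same side of compound 1 as compound 2, while a 1.2-fold lower number from compound 2 to compound 4 (0.09 log units; within the scatter) leaves compound 2 and compound 4 unordered. Replacing the hydroxy with an arylamino group therefore has no single outcome across these compounds, with compound 3 going against the rise seen for compound 2 and compound 4, and no supporting measurement here accounts for the difference.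

The compounds shown leave open how an unsubstituted phenylamino group would compare with the free acid and with the substituted arylamino groups. They also leave open whether a chloro or fluoro group on the same ring, or a simple alkylamino group in place of the arylamino group, would follow compound 3 or compound 4.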